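A few compounds are considered here, and "the series" means these few. Any claim that something is new, unique, unknown or untested is made for them only; others in the source may bear on it.

Measured compounds:
Compound 1, `C/C(=N\NC(=O)COc1cccc2ccccc12)c1ccccc1Br`, gives 79.8 ug/mL in an ADME assay on MT4 cells (Homo sapiens) for cytotoxicity, read by MTT assay, with a stated time of 4 days; on this read-out higher numbers stand for lower toxicity in this test and lower numbers for higher toxicity in this test.
Compound 2, `CSc1ccc(/C=N/NC(=O)COc2cccc3ccccc23)cc1`, gives 68.3 ug/mL in this assay.

Of these two numbers, compound 1 has the higher one, but compound 2 lies within the usual scatter of it, so the pair shows no separation that can be trusted. Compound 3, `C/C(=N\NC(=O)COc1cccc2ccccc12)c1ccc(O)cc1`, has not yet been measured in this assay. It differs from compound 1 in one place: 4-hydroxyphenyl in place of 2-bromophenyl on a carbon with a double bond to nitrogen. Going by the values given here, no step between two measured compounds is known here, so nothing shows what such a change does in this assay, and the only footing is the value of compound 1. The expected step of a 1.1-fold higher number from compound 1 to compound 3 (0.05 log units; within the scatter) is therefore small, within the scatter, leaning if anything toward a higher number. On that footing compound 3 is estimated at 90 ug/mL, with a range from 40 ug/mL to 200 ug/mL.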

Compound 3, half-maximal cytotoxic concentration: 68.8 ug/mL
The estimate for compound 3 lay 1.3-fold (0.12 log units) above the measured number; the measured number falls inside the stated range.
By their numbers in this assay, from the lowest: compounds 2, 3 and 1 (each within the scatter of the next).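

In this assay, going by these compounds alone, the change to 4-hydroxyphenyl in place of 2-bromophenyl on a carbon with a double bond to nitrogen gives the only step at this position so far: a 1.2-fold lower number from compound 1 to compound 3 (0.06 log units; within the scatter). This exchange takes away the bromine and adds 1 hydrogen-bond donor and 1 hydrogen-bond acceptor, yet the two compounds show no separation that can be trusted, so this position tolerates this particular swap without a readable shift in the test. Nothing measured here bears on why the result came out this way.

Still open, going by these compounds, is whether a group of a different kind at this place, such as an amine or a carboxylic acid on the phenyl ring, would move the number beyond the scatter. Also open, on these data alone, is what a longer chain would do in place of the saturated chain carbon on that same carbon.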